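The compounds below may be only part of what the source reports. "The series", "measured", "known", "first", "only" and "open" are said of these compounds alone.

Of the compounds shown here, two have been measured in an assay on HEK293 cells for agonist activity at transient receptor potential cation channel subfamily M member 8 (Homo sapiens), read by fluorescence and calcium flux, with a stated time of 15 min; on this read-out lower numbers stand for an effect already at smaller amounts and higher numbers for an effect only at larger amounts of compound. Compound 1 `CCN(Cc1cccs1)C(=O)COc1ccc(C(F)(F)F)cc1` gives 236 nM in this assay. Compound 2 `Cc1ccc(OCC(=O)N(Cc2cccs2)c2ccncc2)cc1` gives 52 nM in this assay, which is the lower of the two numbers; compound 1 stands at a higher number, and that gap lies beyond the usual scatter of the assay. The two compounds differ in more than one place, so what separates them cannot be traced to a single change.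

Compound 3 `Cc1ccc(OCC(=O)N(Cc2cccs2)c2cnccn2)cc1` has not yet been measured. It differs from compound 2 in one place: pyrazin-2-yl in place of pyridin-4-yl on an amide-type nitrogen. Among the compounds with values here, no measured pair shows this kind of exchange on the amide-type nitrogen, so there is no comparable step to lean on, and the aryl group on that nitrogen is the only thing that changes.

With nothing measured for this exchange, the step from compound 2 to compound 3 is estimated to be small and, if anything, toward a higher number, as a 1.6-fold higher number from compound 2 to compound 3 (0.21 log units; within the scatter). For compound 3 the value in this assay is expected to be about 85 nM, with a range from 25 nM to 300 nM.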

Compound 3, half-maximal effective concentration: 1240 nM
Estimate against measurement, compound 3: 15-fold (1.16 log units) below; the whole stated range lies below it.
By their numbers in this assay, from the lowest: compound 2; then compound 1; then compound 3.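

The step shows that the aryl group on the amide-type nitrogen cannot be exchanged freely in this assay: pyrazin-2-yl in place of pyridin-4-yl gives a 24-fold higher number from compound 2 to compound 3 (1.38 log units; beyond the scatter). The two groups have much in common, as each has 6 heavy atoms, one six-membered aromatic ring, no hydrogen-bond donors and no net charge, yet they differ in that pyrazin-2-yl has 2 ring hetero atoms and 2 hydrogen-bond acceptors where pyridin-4-yl has 1 of each, and in the point at which the ring is attached. Nothing available shows which of these differences lies behind the step.

The compounds shown leave open whether the second ring nitrogen or the point of attachment matters more, a question that pyridin-3-yl, pyridin-2-yl or plain phenyl on the same amide-type nitrogen could help to separate. They also leave open whether this exchange would give a step of similar size in a compound carrying trifluoromethyl in place of the methyl group of compound 2.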